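Replacing the amide substituent of compound 3 with 1H-indazol-5-yl

The source may hold more compounds than are shown below. What is called first, only, known or untested is meant among the compounds shown, and "the series" means these compounds.

Of the compounds shown here, three sharing one core have been measured in an assay on isolated protein for inhibition of histone acetyltransferase p300 (Homo sapiens), with a stated time of 60 min; on this read-out higher numbers stand for weaker inhibition and lower numbers for stronger inhibition. Compound 1 `COc1ccc(NC(=O)[C@H]2CCCN2C(=O)C2(c3cccc(Cl)c3)CCCC2)nc1` gives 2 nM. Compound 2 `O=C(Nc1ccc2[nH]ncc2n1)[C@H]1CCCN1C(=O)C1(c2cccc(Cl)c2)CCCC1` gives 0.159 nM, and compound 3 `O=C1Cc2cc(NC(=O)[C@H]3CCCN3C(=O)C3(c4cccc(Cl)c4)CCCC3)ccc2N1` gives 0.794 nM. Among these, compound 3 holds the second highest number: it sits a 2.5-fold lower number from compound 1 to compound 3 (0.40 log units; beyond the scatter) and a 5.0-fold higher number from compound 2 to compound 3 (0.70 log units; beyond the scatter).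

Compound 4 `O=C(Nc1ccc2[nH]ncc2c1)[C@H]1CCCN1C(=O)C1(c2cccc(Cl)c2)CCCC1` has not yet been measured. It differs from compound 3 in a single place: a group of 9 heavy atoms (7 carbon, 2 nitrogen; one five-membered aromatic ring with 2 hetero atoms, one six-membered aromatic ring of carbon only) in place of a group of 10 heavy atoms (8 carbon, 1 nitrogen, 1 oxygen; one five-membered non-aromatic ring with 1 hetero atom, one six-membered aromatic ring of carbon only), on an amide-type nitrogen. Among the measured compounds shown here, of the measured steps, the one from compound 2 to compound 3 bears most directly on this change, since compound 2 also carries a five-membered aromatic ring with 2 hetero atoms on the amide-type nitrogen; that step was a 5.0-fold higher number from compound 2 to compound 3 (0.70 log units; beyond the scatter). The step of a 13-fold lower number from compound 1 to compound 2 (1.10 log units; beyond the scatter) points the same way. For the measured compounds named here, the group entering in compound 4 lacks the six-membered aromatic ring with 1 hetero atom that compound 2 carries, and no measured pair isolates that difference, so the expected gain is tempered. On balance compound 4 is expected to return a lower number than compound 3 in this assay, a step of about a 2.6-fold lower number from compound 3 to compound 4 (0.42 log units; beyond the scatter), with the estimate for compound 4 being 0.3 nM within a range of 0.1 nM to 1 nM.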

Compound 4, half-maximal inhibitory concentration: 1 nM
Compound 4: the middle estimate sits 3.3-fold (0.52 log units) below what was measured; low and high end bracket the measured number.
By their numbers in this assay, from the lowest: compound 2; then compounds 3, 4 and 1 (each within the scatter of the next, the first and the last beyond it).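

In this assay, putting 1H-indazol-5-yl on the amide-type nitrogen in place of the group of compound 3 gives a 1.3-fold higher number from compound 3 to compound 4 (0.10 log units; within the scatter), so this exchange of one two-ring group for another leaves the read-out unresolved. The closest comparison is with compound 2, where a six-membered aromatic ring of carbon only replaces a six-membered aromatic ring with 1 hetero atom and the result is a 6.3-fold higher number from compound 2 to compound 4 (0.80 log units; beyond the scatter); a five-membered aromatic ring with 2 hetero atoms therefore does not by itself bring compound 4 to the number of compound 2. Against 5-methoxypyridin-2-yl, 1H-indazol-5-yl gives a 2.0-fold lower number from compound 1 to compound 4 (0.30 log units; within the scatter), which leaves compound 2 as the strongest of the four, with its steps to the other three all printed beyond the scatter.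

No measurement shown here explains the gap between compound 2 and compound 4. Also open, on these data alone, is how a pyridin-2-yl carrying an amine in place of the methoxy group would read in this assay, and whether the hetero atom in the six-membered ring of compound 2 would count for as much on the group of compound 3.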